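This account rests on a few compounds, and the source may have more. Where it says the series, first, only, none or still open, it means among the compounds named here.

Measured compounds: compound 1 `COc1ccc(-c2cc(Cl)cc(C(=O)Nc3nn[nH]n3)n2)cc1`, compound 2 `COc1cc(C(=O)Nc2nn[nH]n2)nc(-c2ccccc2)c1` and compound 3 `CCCc1ccc(-c2cc(OC)cc(C(=O)Nc3nn[nH]n3)n2)cc1`. In a functional assay on the whole organism with Rattus norvegicus as the target, at a dose of 3 mg/kg by the oral route (a higher number here means a stronger effect of the compound at the dose given, a lower number a weaker effect), compound 1 gives 100%, compound 2 gives 97% and compound 3 gives 93%.

All three numbers lie within the scatter of one another, so compound 3 stands level with compound 1 and compound 2 on this read-out. Compound 4 `COc1cc(C(=O)Nc2nn[nH]n2)nc(-c2ccc(N(C)C)cc2)c1` differs from compound 3 by dimethylamino in place of propyl on an aromatic carbon. Among the compounds with values here, one measured step concerns the same position: a number 4 percentage points lower from compound 2 to compound 3 (within the scatter), where a new group at that carbon left the read-out essentially unchanged. Within the data shown here, no measured step involves a dimethylamino group. A step no larger than the scatter is therefore expected, estimated as no change at the digits printed from compound 3 to compound 4 (within the scatter). For compound 4 the expected value in this assay is 93%, with a range from 80% to 100%.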

Compound 4, a percentage reported as inhibition, in the whole organism at one dose (the size of the read-out at that dose, not a potency): 100%
Compound 4: the middle estimate sits 7 percentage points below what was measured; the range from low to high includes it.
By their numbers in this assay, from the lowest: compounds 3, 2, 1 and 4 (each within the scatter of the next).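

Putting dimethylamino in place of propyl on this aromatic carbon gives a number 7 percentage points higher from compound 3 to compound 4 (within the scatter) in this assay, and putting it in place of hydrogen gives a number 3 percentage points higher from compound 2 to compound 4 (within the scatter). So this position also accepts a group containing nitrogen, with a hydrogen-bond acceptor that propyl lacks, and the read-out stays level. Nothing measured here offers an explanation for this.

As far as these compounds go, whether a carboxylic acid or a longer chain at this carbon would stand apart remains open. With a single dose, these numbers also cannot separate the compounds by potency.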